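Sugar Replaced by Methyl: Expected Cytotoxicity of Compound 3

This account rests on a few compounds, and the source may have more. Where it says the series, first, only, none or still open, it means among the compounds named here.

Compound 1, `CCCCCCCCC#Cc1cc2cn(C)c(=O)nc2o1`: > 175000 nM
Compound 2, `CCCCCCC#Cc1cc2cn([C@@H]3O[C@H](CO)[C@@H](O)[C@H]3O)c(=O)nc2o1`: > 133000 nM

In a functional assay on HEL cells (Homo sapiens) for cytotoxicity (a lower number here means that less compound is tolerated, a higher number that more compound is tolerated), compound 1 reaches only a limit, > 175000 nM. Compound 2 likewise gives only a limit, > 133000 nM. Among the measured compounds shown here, compound 2 thus stands at a limit rather than at a number, and the one other value shown is a limit as well (the limit of > 133000 nM in this assay, at which 1 of the 2 values shown sits, (the limit of > 175000 nM in this assay, at which 1 of the 2 values shown sits)). Compound 3, `CCCCCCC#Cc1cc2cn(C)c(=O)nc2o1`, differs from compound 2 by methyl in place of 3,4-dihydroxy-5-(hydroxymethyl)oxolan-2-yl on an aromatic nitrogen. For the measured compounds named here, no step between measured compounds is available, and both measured compounds sit at limits, so in this assay no change beyond the scatter is expected: a step that the limit leaves unreadable from compound 2 to compound 3. Compound 3 is estimated at 175000 nM, within 90000 nM to 350000 nM, most likely reported again only as a limit.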

Compound 3, half-maximal cytotoxic concentration: > 194000 nM
Compound 3 gave a limit, no number (the forecaster's own chance of this, stated with the estimate: 85%); at least 1.1-fold (0.04 log units) between middle value and limit.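

Compound 3 gives only a limit, as do compound 1 and compound 2, so neither step to compound 3 can be read. The compounds shown leave open at what concentration any of them reaches the half-maximal effect in this assay, and so whether swapping the sugar for methyl or changing the chain length matters.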